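A few compounds are considered here, and "the series" means these few. Any claim that something is new, unique, unknown or untested is made for them only; others in the source may bear on it.

Measured compounds:
- Compound 1, `Cc1nc2c(CSc3ccccc3)cccn2c1C`: 29%
- Compound 2, `Cc1nc2c(OCc3ccccc3)cccn2c1CCC#N`: 40%
- Compound 3, `[C-]#[N+]Cc1c(C)nc2c(OCc3ccccc3)cccn12`: 96%

In a functional assay on the whole organism with Rattus norvegicus as the target, with a stated time of 4 h, at a dose of 40 mg/kg by the intraperitoneal route (on this read-out higher numbers stand for more inhibition at the one dose given (going by the name of the read-out) and lower numbers for less inhibition), compound 3 stands highest of the three numbers: compound 2 sits a step of a number 56 percentage points higher from compound 2 to compound 3 (beyond the scatter) away, and compound 1 lies further down still, with both gaps beyond the scatter. Compound 4, `CSCc1c(C)nc2c(OCc3ccccc3)cccn12`, has not yet been measured. It differs from compound 3 in one place: a group of 2 heavy atoms (1 carbon, 1 sulfur; no ring) in place of a group of 2 heavy atoms (1 carbon, 1 nitrogen; no ring), on a saturated chain carbon bound to an aromatic carbon. Among the compounds with values here, the only measured step that touches the same position is the one from compound 2 to compound 3, which was large and upward; that step brought in the group that compound 4 now loses, so the same evidence points the other way here. Within the data shown here, no measured pair shows methylsulfanyl in this position, and compound 1, which also carries a sulfur-bearing group on a saturated chain carbon, differs from compound 3 in more than one place, so its value only shows that a lower number is possible. Compound 4 is therefore expected to fall by about a number 51 percentage points lower from compound 3 to compound 4 (beyond the scatter) in this assay, and its estimated value is 45%, within 20% to 75%.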

Compound 4, a percentage reported as inhibition, in the whole organism at one dose (the size of the read-out at that dose, not a potency): 29%
Compound 4: the middle estimate sits 16 percentage points above what was measured; the range from low to high includes it.
By their numbers in this assay, from the lowest: compounds 1 and 4 (each within the scatter of the next); then compound 2; then compound 3.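

At this position, on a saturated chain carbon bound to an aromatic carbon, the read-out in this assay turns on which group is present and not on its size: methylsulfanyl has the same count of heavy atoms as the group it replaces, yet the change gives a number 67 percentage points lower from compound 3 to compound 4 (beyond the scatter). The earlier step from the longer cyanomethyl chain had shown only a rise, and the new result shows that a group of this size can also sit at the low end. Methylsulfanyl also falls short of cyanomethyl, with a number 11 percentage points lower from compound 2 to compound 4 (beyond the scatter), so of these three groups only the one in compound 3 gives a high number.

The compounds shown do not tell whether an amine, a hydroxyl or a longer sulfur chain such as ethylsulfanyl at this position would hold the number up or lose it. No measurement here bears on why these groups differ.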